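Compound 3 as a larger substituent variation of compound 2

This account rests on a few compounds, and the source may have more. Where it says the series, first, only, none or still open, it means among the compounds named here.

Of the compounds shown here, two have been measured in a functional assay on DU-145 cells (Homo sapiens) for cytotoxicity, read by trypan blue exclusion, with a stated time of 96 h; a higher number here means a weaker inhibitor, a lower number a stronger inhibitor. Compound 1 `COc1ccc(/C=C/S(=O)(=O)Nc2c(F)c(F)c(F)c(F)c2F)cc1N` gives 35000 nM in this assay. Compound 2 `COC(=O)CNc1cc(NS(=O)(=O)/C=C/c2c(OC)cc(OC)cc2OC)ccc1OC` gives 350 nM in this assay, the lowest of the two numbers, and its gap to compound 1 lies beyond the scatter. Compound 3 `COc1cc(OC)c(/C=C/S(=O)(=O)Nc2ccc(OC)c(NC(C(=O)O)c3ccc(F)cc3)c2)c(OC)c1` has not yet been measured in this assay. Going by the values given here, it keeps the whole of compound 2 except for one group: carboxy(4-fluorophenyl)methyl in place of (methoxycarbonyl)methyl on a nitrogen on an aromatic ring The change replaces a short chain with one that brings in an aromatic ring and a free acid, and the data hold no measured pair that isolates such a change, so no direct comparison is available to anchor the direction. Compound 3 is therefore expected to remain in the neighbourhood of compound 2, with the step from a 1.4-fold higher number from compound 2 to compound 3 (0.15 log units; within the scatter) expected to be small and its direction uncertain. The estimate for compound 3 in this assay is 500 nM, with a range from 100 nM to 3000 nM.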

Compound 3, half-maximal inhibitory concentration: 75 nM
Compound 3: the middle estimate sits 6.7-fold (0.82 log units) above what was measured, and the stated range ends above it.
By their numbers in this assay, from the lowest: compound 3; then compound 2; then compound 1.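

In this assay the substituent on the nitrogen on an aromatic ring proves open to a much larger group: with carboxy(4-fluorophenyl)methyl in place of (methoxycarbonyl)methyl, the result is a 4.7-fold lower number from compound 2 to compound 3 (0.67 log units; beyond the scatter) and a modest gain rather than a loss. Going by these compounds alone, the earlier compounds offered no step at this place, so this is the first sign that the number responds to what the nitrogen carries, and that a group with a six-membered aromatic ring and a free acid is accepted there. Nothing measured here explains why the number falls with this change.

The single step brings in the 4-fluorophenyl ring and replaces the methyl ester with a carboxylic acid at once, so the compounds shown cannot assign the gain to either part. From the compounds shown here alone, a carboxymethyl group with no ring, a methyl ester that keeps the 4-fluorophenyl ring, or a plain phenyl ring without the fluorine would separate these contributions, and whether an amine or a longer chain would serve at this nitrogen remains open.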